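A few compounds are considered here, and "the series" means these few. Any claim that something is new, unique, unknown or untested is made for them only; others in the source may bear on it.

Measured compounds:
Compound 1, `CCCc1nc(C)c2c(CC)nnc(SC)n12`: > 48000 nM in a functional assay for inhibition, with Homo sapiens as the target; a higher number here means a weaker inhibitor, a lower number a stronger inhibitor
Compound 2, `CCCc1nc(C)c2cnnc(SC)n12`: > 48000 nM
Compound 3, `Cc1ncn2c(Nc3cc[nH]n3)nccc12`: 57000 nM

Compound 1 is reported only as a limit of this assay, > 48000 nM, not as a number. Compound 2 likewise stands at a limit, > 48000 nM, and no number is given for it. Compound 3 is the only one of the three with a number in this assay, where compound 3 gives 57000 nM.

Compound 1 differs from compound 2 in one place, (ethyl in place of hydrogen on an aromatic carbon). The step that the two limits leave unreadable from compound 2 to compound 1 cannot be read, since both ends sit at a limit; this follows from the limit of > 48000 nM in this assay, at which 2 of the 3 values shown sit. How the core of compound 3 differs from the core of compound 2 is not broken down here.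

Compound 4, `CCc1nc(C)c2ccnc(Nc3cc[nH]n3)n12`, has not been measured in this assay. It differs from compound 3 by ethyl in place of hydrogen on an aromatic carbon. Among the measured compounds shown here, this is the same kind of change as the one from compound 2 to compound 1, but the surroundings differ: in compound 4 the ethyl enters on a five-membered aromatic ring with 2 nitrogen, between two ring nitrogen atoms, whereas in compound 1 it enters on a six-membered aromatic ring with 3 nitrogen, next to the ring nitrogen and para to a methylsulfanyl group. The earlier step gives no readable size, so the expectation for compound 4 rests on compound 3 alone, whose 57000 nM is weak, and the step from compound 3 to compound 4 is expected to be about a 1.1-fold lower number from compound 3 to compound 4 (0.06 log units; within the scatter). Compound 4 is therefore expected to give about 50000 nM in this assay, estimated between 15000 nM and 150000 nM.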

Compound 4, half-maximal inhibitory concentration: 13000 nM
Estimate against measurement, compound 4: 3.8-fold (0.59 log units) above, and the stated range ends above it.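

In this assay, ethyl in place of hydrogen on an aromatic carbon gives a 4.4-fold lower number from compound 3 to compound 4 (0.64 log units; beyond the scatter), so on the core of compound 3 this change goes with a lower number, which here means a stronger inhibitor. The same change on the core of compound 2, which leads to compound 1, cannot be read, so this series offers no second size to set beside the first: the limit of > 48000 nM in this assay, at which 2 of the 4 values shown sit. The result therefore does not show that the change carries from one core to another, since it rests on a single readable step on a single core, and nothing here tells whether the core of compound 2 would respond in the same direction or to the same extent.

The compounds shown leave open whether a longer chain, an amine or a carboxylic acid in place of the ethyl on compound 4 would lower the number further, keep it where it is or raise it. They also leave open whether another group in place of the methylsulfanyl group of compound 2 would bring that core to a readable number, against which the ethyl change could then be sized.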